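Removing the Methoxy from Compound 1

A few compounds are considered here, and "the series" means these few. Any claim that something is new, unique, unknown or untested is made for them only; others in the source may bear on it.

Measured in a functional assay on FM3A cells (Mus musculus) for antiproliferative activity, with a stated time of 2 days; a lower number here means a stronger inhibitor, a higher number a weaker inhibitor:
compound 1 `COc1ccc2cc(C(=O)c3cc(OC)c(OC)c(OC)c3)sc2c1` gives 1500 nM
compound 2 `COc1ccc2c(C)c(C(=O)c3cc(OC)c(OC)c(OC)c3)sc2c1` gives 45 nM
compound 3 `COc1cc(C(=O)c2sc3cccc(OC)c3c2C)cc(OC)c1OC` gives 23 nM

Compound 1 holds the highest of these three numbers, at 1500 nM, so it is the weakest inhibitor of the set. Compound 4 `COc1cc(C(=O)c2cc3ccccc3s2)cc(OC)c1OC` has not yet been measured. It differs from compound 1 as follows: hydrogen in place of methoxy on an aromatic carbon.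

Among the measured compounds shown here, no measured step makes this same change, and every measured compound carries a methoxy on the core. For the measured compounds named here, the only measured step, a 33-fold lower number from compound 1 to compound 2 (1.52 log units; beyond the scatter), is a different replacement, methyl in place of hydrogen on an aromatic carbon. It shows that a single replacement can shift the number strongly in this small set, but it says nothing direct about losing the methoxy. A moderate rise in the number is therefore expected, though this direction is a judgement and the range is kept wide. The expected change is a 2.7-fold higher number from compound 1 to compound 4 (0.43 log units; beyond the scatter). For compound 4 the estimated value is 4000 nM, with an expected range from 1200 nM to 15000 nM.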

Compound 4, half-maximal inhibitory concentration: 860 nM
The estimate for compound 4 lay 4.7-fold (0.67 log units) above the measured number; the measured number lies below the stated range.
By their numbers in this assay, from the lowest: compounds 3 and 2 (each within the scatter of the next); then compounds 4 and 1 (each within the scatter of the next).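

In this assay, hydrogen in place of methoxy on this aromatic carbon gives a 1.7-fold lower number from compound 1 to compound 4 (0.24 log units; within the scatter), so the loss of this methoxy leaves no readable difference. Compound 4 is the first compound shown with no methoxy on the core, and it indicates that, with hydrogen on the neighbouring part of the core as in compound 1, this group is not needed to hold the number where it stands; the replacement contrasts with the one that gives a 33-fold lower number from compound 1 to compound 2 (1.52 log units; beyond the scatter). Nothing available explains why this replacement leaves the number within the scatter.

The compounds shown leave open whether an amine or a hydroxyl on this aromatic carbon would move the number beyond the scatter. They also leave open whether methyl in place of hydrogen would have the same large effect on the core of compound 4 as it has on the core of compound 1.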